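The compounds below may be only part of what the source reports. "The series", "measured", "known", "first", "only" and "open" are said of these compounds alone.

Measured so far in a functional assay (muscle tissue) with Rattus norvegicus as the target; on this read-out lower numbers stand for an effect already at smaller amounts and higher numbers for an effect only at larger amounts of compound:
- compound 1 `CCCCNC(=O)C1=CC(C)(C)Oc2ccc([N+](=O)[O-])cc21`: 21.9 nM
- compound 2 `C#CCNC(=O)C1=CC(C)(C)Oc2ccc([N+](=O)[O-])cc21`: 7.94 nM

Of these two numbers, compound 1 holds the higher one, so it needs the larger amount for its effect. Compound 3 `CC1(C)C=C(C(=O)NCCC#N)c2cc([N+](=O)[O-])ccc2O1` has not yet been measured. Its difference from compound 1 is cyano in place of ethyl on a saturated chain carbon, two bonds along the chain from an amide-type nitrogen. Among the measured compounds shown here, only one measured step bears on this change, and it is modest: a 2.8-fold lower number from compound 1 to compound 2 (0.44 log units; beyond the scatter). There, ethynyl replaced propyl, so the entering group also holds a triple bond. The groups and their places differ, however, so this single step is only a loose guide. A smaller move in the same direction therefore seems likely in this assay. The expected change is a 1.8-fold lower number from compound 1 to compound 3 (0.26 log units; within the scatter). For compound 3 the estimated value is 12 nM, with an expected range from 4 nM to 35 nM.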

Compound 3, half-maximal effective concentration: 2.82 nM
Compound 3: middle estimate off by 4.3-fold (0.63 log units), on the high side; the whole stated range lies above it.
By their numbers in this assay, from the lowest: compound 3; then compound 2; then compound 1.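

In this assay the cyano group, which has the same count of heavy atoms as the ethyl it replaces, gives a 7.8-fold lower number from compound 1 to compound 3 (0.89 log units; beyond the scatter) on this saturated chain carbon, a larger step than the one seen before. A triple bond in the side chain is also not the whole story: compound 2 and compound 3 both hold one, yet the change to cyanomethyl from ethynyl gives a 2.8-fold lower number from compound 2 to compound 3 (0.45 log units; beyond the scatter) beyond the scatter. Nothing measured here explains why the cyano-bearing chain stands lowest.

Still open, from the compounds shown here alone, is how much the chain length matters, for example whether a longer chain carrying the same nitrile keeps this low number. An amine or a carboxylic acid in place of the cyano, on the same saturated chain carbon, would show how specific the effect is to the nitrile.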